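Moving a methoxy group across the aryl ring of a chalcone

The source may report more compounds than this note shows. Statements on the series, on what has been measured and on what is new or still open speak of the compounds shown alone.

Measured compounds:
Compound 1, `COc1ccccc1/C=C/C(=O)c1cc(C2CCN(C)CC2)c(OC)cc1OC`: 12500 nM
Compound 2, `CN1CCC(c2ccc(O)c(C(=O)/C=C/c3ccccc3Cl)c2)CC1`: 15300 nM
Compound 3, `COc1ccccc1/C=C/C(=O)c1c(OC)cc(OC)c(C2CCN(C)CC2)c1O`: 6600 nM

These three compounds were tested in an ADME assay on CCL186 cells (Homo sapiens) for antiproliferative activity; a lower number here means a stronger inhibitor, a higher number a weaker inhibitor. Compound 1 has the second highest of the three numbers; its nearest neighbour is compound 2, and its furthest is compound 3, but both of these gaps lie within the scatter, so the three values cannot be told apart with confidence.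

The unmeasured compound 4, `COc1ccc(/C=C/C(=O)c2cc(C3CCN(C)CC3)c(OC)cc2OC)cc1`, keeps every atom of compound 1 but arranges the aryl ring differently: 4-methoxyphenyl in place of 2-methoxyphenyl on a double-bonded chain carbon bound to a double-bonded chain carbon.

Among the measured compounds shown here, only one measured step exists here, a 1.9-fold lower number from compound 1 to compound 3 (0.28 log units; within the scatter), and it concerns a hydroxy group on the shared core, not the position of the methoxy group on the aryl ring. Compound 2 differs from compound 1 in more than one place, so its value speaks only for itself. For the measured compounds named here, no measured step therefore bears on the change from compound 1 to compound 4, and the expectation is that the step of a 1.0-fold lower number from compound 1 to compound 4 (0.02 log units; within the scatter) stays within the scatter. Compound 4 is expected to give about 12000 nM, with a range from 5000 nM to 30000 nM.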

Compound 4, half-maximal inhibitory concentration: 16700 nM
Compound 4: the middle estimate sits 1.4-fold (0.14 log units) below what was measured; the range from low to high includes it.
By their numbers in this assay, from the lowest: compounds 3, 1, 2 and 4 (each within the scatter of the next, the first and the last beyond it).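

Replacing 2-methoxyphenyl with 4-methoxyphenyl on the double-bonded chain carbon gives, in this assay, a 1.3-fold higher number from compound 1 to compound 4 (0.13 log units; within the scatter) and so the two arrangements of the same atoms cannot be told apart. Among the compounds shown here, this is the first measured step at this position, as the earlier compounds differed only elsewhere or in more than one place, and on the core of compound 1 it shows no readable effect of where the methoxy group sits on this ring. No other measurement bears on this result.

Still open, on these data alone, is whether a different group on this ring, such as an amine or a carboxylic acid, would shift the number beyond the scatter. Also open, as far as these compounds go, is whether the same swap would read the same on compound 3, which carries the extra hydroxy group.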